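This account rests on a few compounds, and the source may have more. Where it says the series, first, only, none or still open, it means among the compounds named here.

Compound 1, `Cc1csc(N)c1C(=O)c1ccc(Cl)cc1`, is the smaller of the two measured compounds; in an assay on CHO cells for displacement of a labelled ligand from adenosine receptor A3 (Homo sapiens), read by scintillation counting, tested at 10 uM (on this read-out lower numbers stand for less inhibition and higher numbers for more inhibition at the one concentration tested (going by the name of the read-out)), compound 1 gives 1%. Compound 2, `CC(C)Cc1csc(N)c1C(=O)c1ccc(Cl)cc1`, carries a longer chain on the same carbon, and in this assay compound 2 gives 1%. Among the compounds with values here, the only measured step, no change at the digits printed from compound 1 to compound 2 (within the scatter), shows that this lengthening left the read-out flat, so compound 2 stands level with compound 1 in this assay and both sit at the floor of the read-out.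

Compound 3, `CC(C)(C)c1csc(N)c1C(=O)c1ccc(Cl)cc1`, has not been measured in this assay. Relative to compound 2 the change is tert-butyl in place of isobutyl on an aromatic carbon. Within the data shown here, the one step that bears on it, from compound 1 to compound 2, is within the scatter, so no step beyond the scatter is expected in this assay for compound 3 either. Compound 3 is therefore expected to give about 2%, between -8% and 12%, an expected step of a number 1 percentage points higher from compound 2 to compound 3 (within the scatter).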

Compound 3, a percentage reported as inhibition, at one concentration (the size of the read-out at that concentration, not a potency): 1%
Estimate against measurement, compound 3: 1 percentage points above; the range from low to high includes it.
By their numbers in this assay, from the lowest: compounds 1, 2 and 3 (each within the scatter of the next).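

In this assay there is no change at the digits printed from compound 2 to compound 3 (within the scatter) when tert-butyl takes the place of isobutyl, so rearranging the same four carbons on this aromatic carbon leaves the read-out flat. The larger swap of tert-butyl for methyl likewise gives no change at the digits printed from compound 1 to compound 3 (within the scatter) and shows that, with the three saturated carbon groups tested here, this position gives no read-out above the floor. Nothing available accounts for this flat result.

Whether any other kind of group on this carbon can raise the read-out stays open: the compounds shown carry no amine, carboxylic acid or phenyl ring there. They also leave open whether a change elsewhere on the shared core, such as an amide in place of the amino group, would lift the read-out.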